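Dropping the methoxy group from compound 1

The source may report more compounds than this note shows. Statements on the series, on what has been measured and on what is new or still open speak of the compounds shown alone.

In an ADME assay on WI-38 cells (Homo sapiens) for cytotoxicity, read by MTT assay, with a stated time of 48 h (on this read-out lower numbers stand for stronger inhibition and higher numbers for weaker inhibition), compound 1 `COc1ccc(NC(=S)OCCNC(=O)C(C)(C)Oc2ccc(Cl)cc2)cc1` gives 780000 nM as its reading, and compound 3 `O=C(Oc1ccc(-c2cc(=S)ss2)cc1)c1cccnc1` gives 734000 nM as its reading, so these two stand level within the usual scatter of repeated measurements. Compound 2 `O=C(NCCOC(=S)Nc1ccc(F)cc1)c1cccnc1` reports > 800000 nM as a limit and not a number.

Compound 4 `CC(C)(Oc1ccc(Cl)cc1)C(=O)NCCOC(=S)Nc1ccccc1` is compound 1 with hydrogen in place of methoxy on an aromatic carbon, para to a large group, and hydrogen in place of methoxy on an aromatic carbon gives the count of that change. Within the data shown here, no pair of tested compounds shows this swap on its own, so the evidence for it is only indirect. Compound 1 at 780000 nM in this assay is the starting point, and no step beyond the scatter is expected from this change in either direction. The estimated 1.1-fold lower number from compound 1 to compound 4 (0.05 log units; within the scatter) is therefore small. Compound 4 may also return only a limit. Compound 4 is expected in this assay at 700000 nM with 350000 nM to 900000 nM as the estimated range.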

Compound 4, half-maximal inhibitory concentration: > 800000 nM
Compound 4 ended at the assay's limit (the forecaster's own chance of this, stated with the estimate: 35%); middle value at least 1.1-fold (0.05 log units) from the limit.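

In this assay, compound 4 gives > 800000 nM, which is a limit of the assay and not a number. Among these compounds, this gives the first direct look at hydrogen in place of methoxy on this aromatic carbon, and what it can report is only a floor: an at least 1.0-fold higher number from compound 1 to compound 4 (0.01 log units; that floor lies within the scatter). The true size of the change cannot be read from that floor, and the same limit appears elsewhere in the set: the limit of > 800000 nM in this assay, at which 2 of the 4 values shown sit.

On these data alone, it remains open whether an amine, a carboxylic acid or a longer chain at this same place would give a reading that is a number rather than a limit. As far as these compounds go, it also remains open whether the swap would look the same on a compound whose reading sits well clear of the limit.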